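The source may hold more compounds than are shown below. What is called first, only, known or untested is meant among the compounds shown, and "the series" means these compounds.

Measured so far in an assay on brain for displacement of a labelled ligand from 5-hydroxytryptamine receptor 4 (Cavia porcellus), with a stated time of 30 min, in the presence of a further agent that is not named here; a lower number here means a stronger inhibitor, a higher number a weaker inhibitor:
- compound 2 `COc1ccc(S(=O)(=O)NCCN2CCC(CCC(=O)c3cc(Cl)c(N)cc3OC)CC2)cc1OC`: 8.2 nM
- compound 1 `COc1ccc(S(=O)(=O)NCCN2CCC(CCC(=O)c3cc(Cl)c(N)cc3OC)CC2)cc1Br`: 24.3 nM

Among the compounds with values here, compound 2 gives the lowest of the two numbers in this assay, with compound 1 the nearest; the only step in the set, a 3.0-fold lower number from compound 1 to compound 2 (0.47 log units; beyond the scatter), is modest but beyond the scatter. Compound 3 `COc1cc(N)c(Cl)cc1C(=O)CCC1CCN(CCNS(=O)(=O)c2ccc(OC)c(N3CCN(C)CC3)c2)CC1` differs from compound 2 in one place: 4-methylpiperazin-1-yl in place of methoxy on an aromatic carbon. Within the data shown here, no measured step bears directly on this change; the single step from bromo to methoxy at the same position shows that the site tolerates a small change of group with a modest shift, but nothing on the entry of a six-membered non-aromatic ring with two hetero atoms. The expected step of a 1.8-fold higher number from compound 2 to compound 3 (0.26 log units; within the scatter) is therefore taken as small, with direction uncertain and a slight lean toward a higher number, since the entering group is much larger than what it replaces. Compound 3 is estimated at 15 nM in this assay, with a range from 4 nM to 60 nM.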

Compound 3, inhibition constant: 3.46 nM
Compound 3: the middle estimate sits 4.3-fold (0.64 log units) above what was measured, and the stated range ends above it.
By their numbers in this assay, from the lowest: compound 3; then compound 2; then compound 1.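

In this assay, the aromatic carbon ortho to a methoxy group accepts 4-methylpiperazin-1-yl, a group of 7 heavy atoms with a six-membered non-aromatic ring, in place of methoxy, with a 2.4-fold lower number from compound 2 to compound 3 (0.37 log units; beyond the scatter) and thus no penalty for the larger group. Set against bromo at the same carbon, the same group gives a 7.0-fold lower number from compound 1 to compound 3 (0.85 log units; beyond the scatter) and extends the order within these three compounds to bromo, methoxy and then 4-methylpiperazin-1-yl, from the highest number to the lowest. No supporting measurement is available to explain this order.

The compounds shown leave open whether the lower number depends on the second ring nitrogen or on its methyl group. Morpholin-4-yl, piperidin-1-yl, unsubstituted piperazin-1-yl or an open-chain dimethylamino group at this carbon would separate these possibilities.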